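A few compounds are considered here, and "the series" means these few. Any claim that something is new, unique, unknown or untested is made for them only; others in the source may bear on it.

Measured compounds:
- compound 1, `COC(=O)/C=C/c1cccc(N(Cc2ccc(/C=C/c3ccccn3)cc2)C(=O)C2CCCCC2)c1`, 309 nM in an assay on isolated protein with Bile acid receptor (Homo sapiens) as the target; a higher number here means that more compound is needed for the effect, a lower number that less compound is needed
- compound 2, `CCOc1cccc(-c2ccc(CN(C(=O)C3CCCCC3)c3cccc(/C=C/C(=O)OC)c3)cc2)c1`, 147 nM in this assay
- compound 3, `COC(=O)/C=C/c1cccc(N(Cc2ccccc2)C(=O)C2CCCCC2)c1`, > 1000 nM in this assay

Compound 3 stands at the bottom of the three on the numbers shown. Its value in this assay is only a limit of the assay and not a number, (the limit of > 1000 nM in this assay, at which 1 of the 3 values shown sits), so its distance from the other two is known only as a lower bound. Going from compound 1 to compound 3 the number rises, an at least 3.2-fold higher number from compound 1 to compound 3 (0.51 log units; beyond the scatter), and going from compound 2 to compound 3 it rises as well, an at least 6.8-fold higher number from compound 2 to compound 3 (0.83 log units; beyond the scatter). Both steps replace a substituent on the same aromatic carbon by hydrogen, and both run in the same direction.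

Compound 4, `COC(=O)/C=C/c1cccc(N(Cc2ccc(/C=C/C(=O)N(C)C)cc2)C(=O)C2CCCCC2)c1`, not yet measured, reverses that pattern: 2-(dimethylcarbamoyl)ethenyl in place of hydrogen on an aromatic carbon. The group entering is a two-double-bond chain with one hydrogen-bond acceptor, placed on an aromatic carbon of a six-membered aromatic ring of carbon only, para to a large group. The two measured steps that bear on it both show a substituent at this position giving a lower number than hydrogen, so in this assay a lower number is expected for compound 4 than for compound 3, beyond the scatter, with the expected step being an at least 2.5-fold lower number from compound 3 to compound 4 (0.39 log units; beyond the scatter). Because compound 3 stands at a limit, (the limit of > 1000 nM in this assay, at which 1 of the 3 values shown sits), the size of that step is uncertain. For compound 4 the estimate in this assay is 400 nM, between 150 nM and 1500 nM.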

Compound 4, half-maximal effective concentration: > 1000 nM
Compound 4 gave a limit, no number; the forecaster's own chance of this, stated with the estimate: 20%; middle value at least 2.5-fold (0.39 log units) away from the limit.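

In this assay compound 4 gives > 1000 nM, which is a limit of the assay and not a number. A substituent on this aromatic carbon therefore does not by itself secure a lower number than hydrogen: the ethenyl chain is present in both compound 1 and compound 4, yet exchanging its pyridin-2-yl end for dimethylcarbamoyl gives an at least 3.2-fold higher number from compound 1 to compound 4 (0.51 log units; beyond the scatter), and 2-(dimethylcarbamoyl)ethenyl in place of 3-ethoxyphenyl gives an at least 6.8-fold higher number from compound 2 to compound 4 (0.83 log units; beyond the scatter). The step between compound 3 and compound 4 cannot be read, because both values are limits, so the dimethylcarbamoyl group cannot be placed relative to hydrogen: the limit of > 1000 nM in this assay, at which 2 of the 4 values shown sit.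

Within these compounds, the numbers below the limit occur only where the entering group ends in an aromatic ring, as in compound 1 and compound 2, but four compounds cannot show whether that ring is required. Also open, on these data alone, is what a carboxylic acid, a primary amine or a phenyl ring would give at the end of the same ethenyl chain, and whether a longer chain would change the result.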